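A Cyclopentylamino Swap with No Measured Starting Point

A few compounds are considered here, and "the series" means these few. Any claim that something is new, unique, unknown or untested is made for them only; others in the source may bear on it.

compound 1 `OC[C@H]1O[C@@H](n2cnc3c(Nc4ccccc4)nc(NC4CCCC4)nc32)[C@H](O)[C@@H]1O` - 36300 nM
compound 2 `COc1nc(NCc2cccc(I)c2)c2ncn([C@@H]3O[C@H](CO)[C@@H](O)[C@H]3O)c2n1` - "not determined" (no result reported)

Among the compounds with values here, in an ADME assay on L6 cells (Rattus norvegicus) for cytotoxicity (on this read-out lower numbers stand for stronger inhibition and higher numbers for weaker inhibition), compound 1 gives 36300 nM as the only number available. Compound 2 has no number to stand on, its entry being "not determined" (no result reported) in this series. The compound still to be measured is compound 3 `OC[C@H]1O[C@@H](n2cnc3c(NCc4cccc(I)c4)nc(NC4CCCC4)nc32)[C@H](O)[C@@H]1O`, which is derived from compound 2 by a single change. The change cyclopentylamino in place of methoxy on an aromatic carbon puts cyclopentylamino in place of methoxy on an aromatic carbon, between two ring nitrogen atoms. Within the data shown here, with no measured starting value, no step can be sized directly. Among the measured compounds shown here, the only anchor is compound 1 at 36300 nM, and no difference from it beyond the scatter is expected in this assay. For compound 3 the estimated value is 25000 nM, with an expected range of 6000 nM to 90000 nM in this read-out.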

Compound 3, half-maximal inhibitory concentration: 51700 nM
Estimate against measurement, compound 3: 2.1-fold (0.32 log units) below, and the stated range covers the measured number.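

Within the data shown here, with cyclopentylamino held in place on the shared core, 3-iodobenzyl in place of phenyl on the nitrogen on an aromatic ring gives a 1.4-fold higher number from compound 1 to compound 3 (0.15 log units; within the scatter) in this assay, the first step that can be read. On these two compounds, the 3-iodobenzyl group therefore brings no difference beyond the usual scatter in this read-out. The step for cyclopentylamino in place of methoxy cannot be read, as compound 2 has no value, and no measured evidence bearing on this result is available.

The compounds shown leave open how a plain benzyl group or a 3-chlorobenzyl group on that nitrogen would read. They also leave open what an open-chain amine such as propylamino or a six-membered cyclohexylamino group would give between the two ring nitrogen atoms.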